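Anilide series: the step from compound 2 to compound 3

The compounds below may be only part of what the source reports. "The series", "measured", "known", "first", "only" and "open" are said of these compounds alone.

Measured so far:
compound 1 `O=C(Nc1cc(Cl)cc(Cl)c1)c1cnc(O)nc1C(F)(F)F`: > 10000 nM
compound 2 `O=C(Nc1cc(C(F)(F)F)cc(C(F)(F)F)c1)c1cnc(Cl)nc1C(F)(F)F`: 50 nM

Among the measured compounds shown here, in an assay on Jurkat cells for inhibition of cyclic AMP-dependent transcription factor ATF-1 (Homo sapiens) (on this read-out higher numbers stand for weaker inhibition and lower numbers for stronger inhibition), compound 2 gives 50 nM, the only real number in the set. Compound 1 gives > 10000 nM in this assay, which is a limit and not a number (the limit of > 10000 nM in this assay, at which 1 of the 2 values shown sits). Compound 1 and compound 2 differ in more than one place, so no single change can be read from them. Compound 3 `CCOC(=O)c1cc(NC(=O)c2cnc(Cl)nc2C(F)(F)F)cc(C(F)(F)F)c1` awaits measurement; it differs from compound 2 by ethoxycarbonyl in place of trifluoromethyl on an aromatic carbon. For the measured compounds named here, no measured step covers such a change, so a modest loss is expected, estimated as a 3.0-fold higher number from compound 2 to compound 3 (0.48 log units; beyond the scatter). Compound 3 is estimated at 150 nM, within 30 nM to 1000 nM.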

Compound 3, half-maximal inhibitory concentration: 150 nM
For compound 3 middle estimate and measured number coincide at the digits printed; measured number inside the range.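

In this assay, among the compounds shown here, ethoxycarbonyl in place of trifluoromethyl on an aromatic carbon gives a 3.0-fold higher number from compound 2 to compound 3 (0.48 log units; beyond the scatter) and so provides the first single-place reading. This place, meta to a trifluoromethyl group, tolerates the larger ester with a modest loss, and compound 3 stays in measurable range. No available evidence bears on the reason for this loss.

Open, on these data alone, is how the free carboxylic acid, an amine or a longer ester chain would read at this place. Also open, as far as these compounds go, is whether the same change at the remaining trifluoromethyl group would add a further loss.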